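Swapping trifluoromethoxy for trifluoromethyl on two cores

The source may report more compounds than this note shows. Statements on the series, on what has been measured and on what is new or still open speak of the compounds shown alone.

Three compounds share the same overall shape but come in two cores. Compound 1 `CCN(CC)c1ccc2nc(-c3ccccc3OC(F)(F)F)[nH]c(=O)c2c1` and compound 2 `CCN(CC)c1ccc2nc(-c3ccccc3C(F)(F)F)[nH]c(=O)c2c1` carry a diethylamino group on one core; compound 3 `Cc1ccc2c(=O)[nH]c(-c3cccc(OC(F)(F)F)c3)nc2c1` and the still unmeasured compound 4 `Cc1ccc2c(=O)[nH]c(-c3cccc(C(F)(F)F)c3)nc2c1` carry a methyl group on another. The difference between the two cores is not broken down here.

In a functional assay on HeLa cells (Homo sapiens) for cytotoxicity, read by MTT assay, with a stated time of 2 days (a higher number here means a weaker inhibitor, a lower number a stronger inhibitor), compound 1 gives 40 nM. Compound 2 gives 100 nM. The step between them, a 2.5-fold higher number from compound 1 to compound 2 (0.40 log units; beyond the scatter), corresponds to trifluoromethyl in place of trifluoromethoxy on an aromatic carbon, with the group sitting ortho to a large group.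

For compound 3 this assay reports only a limit, > 50000 nM, and not a number, because compound 3 sits at the limit of > 50000 nM in this assay, at which 1 of the 3 values shown sits.

Compound 4 differs from compound 3 by trifluoromethyl in place of trifluoromethoxy on an aromatic carbon. Here the group sits meta to a large group, so this is the same kind of change as the one from compound 1 to compound 2, not the same change. The earlier step made the number higher, and applied to compound 3 it would only move further past the limit, so the expected step from compound 3 to compound 4, a step that the limit leaves unreadable from compound 3 to compound 4, rests on the limit of compound 3 at the limit of > 50000 nM in this assay, at which 1 of the 3 values shown sits, and on the measured step of a 2.5-fold higher number from compound 1 to compound 2 (0.40 log units; beyond the scatter). For compound 4 the estimate in this assay is 80000 nM, from 25000 nM to 300000 nM, and most likely the assay will again report only a limit.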

Compound 4, half-maximal inhibitory concentration: > 50000 nM
Compound 4 ended at the assay's limit; the forecaster's own chance of this, stated with the estimate: 85%; the middle value does not contradict the limit.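

In this assay compound 4 gives > 50000 nM as a limit and not a number, so, with compound 3 also at a limit, no step between compound 3 and compound 4 can be read: the limit of > 50000 nM in this assay, at which 2 of the 4 values shown sit.

The compounds shown leave open whether trifluoromethyl in place of trifluoromethoxy changes the result at all on the core of compound 3, and how any such change would compare with the step seen on the core of compound 1.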